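The compounds below may be only part of what the source reports. "The series", "measured", "known", "first", "only" and "open" are said of these compounds alone.

In a functional assay on A2780 cells (Homo sapiens) for antiproliferative activity, read by fluorescence, with a stated time of 72 h (a lower number here means a stronger inhibitor, a higher number a weaker inhibitor), compound 1 `CC(C)(C)C(=O)N1Cc2c(NC(=O)c3cccnc3)n[nH]c2C1(C)C` gives 690 nM, while compound 2 `CN1CCC(C(=O)N2Cc3c(NC(=O)c4cccs4)n[nH]c3C2(C)C)CC1` gives 30 nM. Compound 2 therefore holds the lower of the two available numbers, and its gap to compound 1, the nearest value, lies well beyond the usual scatter of repeated measurements. Compound 3 `CC1(C)c2[nH]nc(NC(=O)c3ccc(F)cc3)c2CN1C(=O)N1CCN(c2ccccc2)CC1` offers no comparison, as its entry reads "not determined" (no result reported).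

The next compound to consider is compound 4 `CN1CCC(C(=O)N2Cc3c(NC(=O)c4cccc(F)c4)n[nH]c3C2(C)C)CC1`, which differs from compound 2 in one place: 3-fluorophenyl in place of thiophen-2-yl on a carbonyl carbon. Put simply, 3-fluorophenyl stands in place of thiophen-2-yl on a carbonyl carbon, and the rest of the molecule stays the same.

Within the data shown here, no pair of measured compounds differs in only one place, so the data show no direct precedent for this swap. Both groups are single aromatic rings on the same carbonyl, so only a modest change is expected. Among the measured compounds shown here, compound 2, at 30 nM, has the lowest number so far, so any shift is expected to lean towards a higher number, meaning a slightly weaker inhibitor. The expected change is a 1.5-fold higher number from compound 2 to compound 4 (0.18 log units; within the scatter), which would be small and close to the scatter. Compound 4 is estimated at 45 nM, with an expected range of 15 nM to 140 nM.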

Compound 4, half-maximal inhibitory concentration: 200 nM
For compound 4 the middle estimate is 4.4-fold (0.65 log units) below the measured one, outside the stated range (above it).
By their numbers in this assay, from the lowest: compound 2; then compound 4; then compound 1.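

In this assay, putting 3-fluorophenyl in place of thiophen-2-yl on a carbonyl carbon gives a 6.7-fold higher number from compound 2 to compound 4 (0.82 log units; beyond the scatter), so this position does not treat the two aromatic rings alike. Among these compounds, this is the first single-place step in the set, and it shows that changing only this group, with the rest of the molecule held the same, moves the number by more than the usual scatter of repeated measurements. No measurement shown here accounts for the difference.

This single pair changes the ring and adds a fluorine together, so plain phenyl, which has no fluorine, or thiophen-3-yl on the same carbonyl would be needed to read those two parts separately. As far as these compounds go, it also stays open whether the same swap would give a similar step with a different group on the other amide of the shared core, such as a longer alkyl chain.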